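This account rests on a few compounds, and the source may have more. Where it says the series, first, only, none or still open, it means among the compounds named here.

Measured compounds:
- Compound 1, `COc1cc(OC)cc(C(=O)NC2CCN(Cc3ccc4ccccc4c3)CC2)c1`, in an assay on isolated protein for binding affinity to melanin-concentrating hormone receptor 1 (Homo sapiens) (a higher number here means a weaker inhibitor, a lower number a stronger inhibitor), gives 27 nM.
- Compound 2, `O=C(NC1CCN(Cc2ccc3ccccc3c2)CC1)c1cc(F)cc(F)c1`, in this assay gives 65 nM.

Compound 1 stands at the lowest of the two numbers; the nearest is compound 2, and the step of a 2.4-fold higher number from compound 1 to compound 2 (0.38 log units; beyond the scatter) is modest but beyond the scatter. That step exchanges the aryl group on the carbonyl carbon and leaves the rest of the shared core untouched.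

Compound 3, `COc1cc(OC)cc(C(=O)NC2CCN(Cc3ccc4cc(F)ccc4c3)CC2)c1`, keeps the 3,5-dimethoxyphenyl of compound 1 and changes the other end of the molecule: fluoro in place of hydrogen on an aromatic carbon, on the fused system of two rings, at a carbon meta to a fused ring and para to a fused ring. Among the compounds with values here, no measured step touches this part of the core, so the only measured step, from compound 1 to compound 2, does not bear on it directly; it shows merely that the binding is not indifferent to substituent pattern on the shared core. With nothing to anchor a direction, a step within the scatter is expected, a 1.1-fold lower number from compound 1 to compound 3 (0.03 log units; within the scatter). Compound 3 is therefore estimated at 25 nM, in the range 10 nM to 65 nM.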

Compound 3, inhibition constant: 32 nM
For compound 3 the middle estimate is 1.3-fold (0.11 log units) below the measured one; the measured number falls inside the stated range.
By their numbers in this assay, from the lowest: compounds 1 and 3 (each within the scatter of the next); then compound 2.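

In this assay, fluoro in place of hydrogen on an aromatic carbon of the fused system of two rings, at the carbon meta to a fused ring and para to a fused ring, gives a 1.2-fold higher number from compound 1 to compound 3 (0.07 log units; within the scatter), and this step lies within the scatter. It is the first step shown at this end of the molecule, and it indicates that, with the 3,5-dimethoxyphenyl kept in place, this one replacement leaves the number indistinguishable from that of compound 1, whereas the change at the other end, a 2.4-fold higher number from compound 1 to compound 2 (0.38 log units; beyond the scatter), lies beyond the scatter. Nothing available explains why this position and this change give such a result.

The compounds shown leave open whether a larger or differently built group at this same carbon, such as chloro, a nitrile or an amine, would also stay within the scatter of compound 1, since a single fluoro says little about the room for change here. They also leave open whether fluoro on this carbon would give a similar result alongside the 3,5-difluorophenyl of compound 2.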